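A few compounds are considered here, and "the series" means these few. Any claim that something is new, unique, unknown or untested is made for them only; others in the source may bear on it.

Measured in an ADME assay on CRL8155 cells (Homo sapiens) for cytotoxicity, read by resazurin assay, with a stated time of 72 h; on this read-out higher numbers stand for an effect only at larger amounts of compound and lower numbers for an effect already at smaller amounts:
- Compound 1 `O=C(c1ccccc1)c1ccc2nc(NCCO)[nH]c2c1`: > 30000 nM, a limit
- Compound 2 `O=C(NCCCCO)Nc1nc2ccc(C(=O)c3ccccc3)cc2[nH]1`: > 30000 nM, a limit
- Compound 3 `O=C(NCCC1CCNCC1)Nc1nc2ccc(C(=O)c3ccccc3)cc2[nH]1`: > 30000 nM, a limit

Compound 3 gives no number, only this limit, and the same holds across the series: the limit of > 30000 nM in this assay, at which 3 of the 3 values shown sit.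

Compound 4 `NCCCCCCC(=O)Nc1nc2ccc(C(=O)c3ccccc3)cc2[nH]1` carries 6-aminohexyl in place of (2-(piperidin-4-yl)ethyl)amino on a carbonyl carbon.

Within the data shown here, two measured steps bear on this change, and neither has a readable size: a step that the two limits leave unreadable from compound 1 to compound 2 and a step that the two limits leave unreadable from compound 2 to compound 3. No step beyond the usual scatter is therefore expected in this assay, and the series gives no direction. The expected step is an at least 1.0-fold lower number from compound 3 to compound 4 (0.02 log units; that floor lies within the scatter). For compound 4 the estimate is 28000 nM, with an expected range from 10000 nM to 40000 nM.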

Compound 4, half-maximal effective concentration: > 30000 nM
Compound 4 was reported as a limit; the forecaster's own chance of this, stated with the estimate: 75%; middle value at least 1.0-fold (0.02 log units) from the limit.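

No new step can be read between compound 4 and compound 1, compound 2 or compound 3, as all four sit at one limit: the limit of > 30000 nM in this assay, at which 4 of the 4 values shown sit.

The compounds shown leave open whether any of these changes shifts the half-maximal effective concentration at all.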